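Swapping a Diazepane Side Chain for Methoxy

The source may hold more compounds than are shown below. What is called first, only, known or untested is meant among the compounds shown, and "the series" means these compounds.

Measured so far:
Compound 1 `Cc1ccc(NC(=O)c2ccc(CN3CCCN(C)CC3)cc2)cc1-n1cc(-c2cnc3ccnn3c2)cn1` — in an ADME assay on HEK-293T cells (Homo sapiens) for cytotoxicity, read by CCK-8 assay, with a stated time of 24 h (on this read-out higher numbers stand for lower toxicity in this test and lower numbers for higher toxicity in this test), compound 1 gives 20500 nM.
Compound 2 `Cc1ccc(NC(=O)c2cccc(C(F)(F)F)c2)cc1-n1cc(-c2cnc3cccnn23)cn1` — in this assay compound 2 gives 40300 nM.

Compound 1 holds the lower of these two numbers, but its gap to compound 2 falls within the usual scatter, so the two cannot be ranked. Compound 3 `COc1ccc(C(=O)Nc2ccc(C)c(-n3cc(-c4cnc5ccnn5c4)cn3)c2)cc1` differs from compound 1 by methoxy in place of (4-methyl-1,4-diazepan-1-yl)methyl on an aromatic carbon. Going by the values given here, no measured pair shares this change, so its effect in this assay has no precedent here. The author expects a small upward step a 1.5-fold higher number from compound 1 to compound 3 (0.17 log units; within the scatter), hardly beyond the scatter. Compound 3 is therefore estimated at 30000 nM, with a range from 10000 nM to 90000 nM.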

Compound 3, half-maximal cytotoxic concentration: > 80000 nM
Compound 3: a limit, no number; the forecaster's own chance of this, stated with the estimate: 20%; at least 2.6-fold (0.42 log units) between middle value and limit.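

In this assay, going by these compounds alone, the change gives an at least 3.9-fold higher number from compound 1 to compound 3 (0.59 log units; beyond the scatter) at this aromatic carbon, the first step here beyond the scatter, so the group held there can shift the read-out toward lower toxicity in this test. The entry for compound 3 is a limit of the assay, not a number: the limit of > 80000 nM in this assay, at which 1 of the 3 values shown sits.

The compounds shown do not separate the loss of the (4-methyl-1,4-diazepan-1-yl)methyl group from the arrival of methoxy. As far as these compounds go, it stays open whether a smaller amine such as dimethylaminomethyl, or a carboxylic acid, at this carbon would read like compound 1 or compound 3.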